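Long-chain ethers on the isoflavone core: removing the terminal acid

The source may report more compounds than this note shows. Statements on the series, on what has been measured and on what is new or still open speak of the compounds shown alone.

Measured compounds in an assay (Cricetulus griseus) for inhibition of aldehyde dehydrogenase, mitochondrial (Homo sapiens); a lower number here means a stronger inhibitor, a higher number a weaker inhibitor:
- compound 1, `O=c1c(-c2ccc(O)cc2)coc2cc(OCCCCCCCCCO)ccc12`: 700 nM
- compound 2, `O=c1c(-c2ccc(O)cc2)coc2cc(OCCCCCCO)ccc12`: 120 nM
- compound 3, `O=C(O)CCCCCCCCCCCCCCCOc1ccc2c(=O)c(-c3ccc(O)cc3)coc2c1`: a limit, > 9000 nM

Compound 3 stands apart from the other two. Its value in this assay is a limit of the measurement, not a number, as shown by the limit of > 9000 nM in this assay, at which 1 of the 3 values shown sits. The two steps leading to it are both large and both in the weakening direction: an at least 12-fold higher number from compound 1 to compound 3 (1.10 log units; beyond the scatter) and an at least 75-fold higher number from compound 2 to compound 3 (1.87 log units; beyond the scatter). Within the shorter hydroxy-terminated pair, a 5.8-fold lower number from compound 1 to compound 2 (0.77 log units; beyond the scatter).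

Compound 4, `CCCCCCCCCCCCOc1ccc2c(=O)c(-c3ccc(O)cc3)coc2c1`, is not yet measured. The change from compound 3 is hydrogen in place of 3-carboxypropyl on a saturated chain carbon, ten or more bonds along the chain from an oxygen on an aromatic ring. The two steps that bear on it are those into compound 3, where a carboxy-terminated extension replaced a hydroxy and the number rose beyond the limit. Compound 4 reverses the acid-bearing end and shortens the chain, though it keeps no hydroxy either, so a full return to the range of compound 1 or compound 2 is not assumed. The expected step is an at least 6.0-fold lower number from compound 3 to compound 4 (0.77 log units; beyond the scatter), a return below the limit toward a measurable number. The estimate for compound 4 in this assay is 1500 nM, with a range from 300 nM to 7000 nM.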

Compound 4, half-maximal inhibitory concentration: > 9000 nM
Compound 4: a limit, no number (the forecaster's own chance of this, stated with the estimate: 20%); middle value at least 6.0-fold (0.77 log units) from the limit.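

In this assay the value of compound 4, > 9000 nM, is a limit of the measurement and not a number. The terminal acid is therefore not required for a result at the limit: with the carboxy end gone, the long chain ending in plain hydrogen still gives no measurable number, and the two hydroxy-terminated chains stay clearly apart, with an at least 75-fold higher number from compound 2 to compound 4 (1.87 log units; beyond the scatter) and an at least 12-fold higher number from compound 1 to compound 4 (1.10 log units; beyond the scatter). Among the four compounds, measurable numbers occur only with a terminal hydroxy on a shorter chain, with no compound against this, but the size of the step between the two long chains cannot be read: the limit of > 9000 nM in this assay, at which 2 of the 4 values shown sit.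

The compounds shown do not separate the end group from chain length, since the hydroxy ends sit only on the shorter chains and the other ends only on the longer ones. A terminal hydroxy on a chain as long as that of compound 4 would address this, as would a carboxylic acid or an amine at the end of a chain as short as that of compound 2.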